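Fluoro in Place of Hydrogen Across Two Related Cores

The compounds below may be only part of what the source reports. "The series", "measured", "known", "first", "only" and "open" are said of these compounds alone.

Compound 1, `N=C(N)c1ccc(/N=N/Nc2ccccc2C#Cc2ccccc2)cc1`, gives 5300 nM in a functional assay on PC-3 cells (Homo sapiens) for antiproliferative activity, read by WST assay, with a stated time of 72 h; on this read-out higher numbers stand for weaker inhibition of growth and lower numbers for stronger inhibition of growth.
Compound 2, `N=C(N)c1ccc(/N=N/Nc2cccc(C#Cc3ccccc3)c2)cc1`, gives 5800 nM in this assay.
Compound 3, `N=C(N)c1ccc(/N=N/Nc2ccccc2C#Cc2ccc(F)cc2)cc1`, gives 7400 nM in this assay.

Compound 3 differs from compound 1 by fluoro in place of hydrogen on an aromatic carbon. This change made a step of a 1.4-fold higher number from compound 1 to compound 3 (0.14 log units; within the scatter) in this assay, so the two numbers cannot be told apart. Compound 2 shares all its atoms with compound 1 but they are joined differently; the difference between the two cores is not broken down here. Its value stands close to that of compound 1 and of compound 3, and all three numbers lie within the scatter of one another.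

Compound 4, `N=C(N)c1ccc(/N=N/Nc2cccc(C#Cc3ccc(F)cc3)c2)cc1`, has not yet been measured. It differs from compound 2 by fluoro in place of hydrogen on an aromatic carbon, the same change that separates compound 3 from compound 1, made on the core of compound 2 instead. Because the earlier step of a 1.4-fold higher number from compound 1 to compound 3 (0.14 log units; within the scatter) stayed within the scatter, the step from compound 2 to compound 4 is expected to be of about the same small size, a 1.4-fold higher number from compound 2 to compound 4 (0.14 log units; within the scatter). On that basis compound 4 is estimated to give 8000 nM in this assay, with a range expected from 4000 nM to 16000 nM.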

Compound 4, concentration for 50% growth inhibition: 5300 nM
Compound 4: middle estimate off by 1.5-fold (0.18 log units), on the high side; low and high end bracket the measured number.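

On the second core, fluoro in place of hydrogen on an aromatic carbon made a step of a 1.1-fold lower number from compound 2 to compound 4 (0.04 log units; within the scatter) in this assay, so the swap of phenyl to 4-fluorophenyl again produced no change that can be told from the scatter. Set side by side, the two steps give no sign that the two cores answer this change differently: the same change on two cores in this assay, a 1.4-fold higher number (0.14 log units; within the scatter) from compound 1 to compound 3 and a 1.1-fold lower number (0.04 log units; within the scatter) from compound 2 to compound 4, 1.5-fold (0.18 log units) apart, within the scatter of two such steps. This shows that, on these two cores and in this one assay, the change carries over as a step too small to read, but a carry-over of a step this small says little, and it does not show that a change with a clear effect would transfer in the same way, nor that the same would hold on any other core.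

The compounds shown leave open whether a group other than fluoro at the same place on the terminal ring, such as methoxy, an amine or a carboxylic acid, would move the number beyond the scatter on either core. They also leave open whether such a group would then give steps of the same size on the two cores, which is the comparison that would truly test transfer in this series.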